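The source may report more compounds than this note shows. Statements on the series, on what has been measured and on what is new or still open speak of the compounds shown alone.

Measured compounds:
Compound 1 `COc1cc(-n2ncnc2-c2cccc([N+](=O)[O-])c2)cc(OC)c1OC`; in a functional assay on HL-60 cells (Homo sapiens) for antiproliferative activity, read by MTT assay, with a stated time of 72 h (a higher number here means a weaker inhibitor, a lower number a stronger inhibitor), compound 1 gives > 10000 nM, a limit of the assay.
Compound 2 `COc1cc(-c2ncnn2-c2cccc(N)c2)cc(OC)c1OC`; in this assay compound 2 gives > 10000 nM, a limit of the assay.
Compound 3 `COc1cc(-c2ncnn2-c2ccc(Cl)cc2Cl)cc(OC)c1OC`; in this assay compound 3 gives > 10000 nM, a limit of the assay.

Compound 1 stands only at a limit in this assay, and the same holds for the two other measured compounds, so no order among the three can be read. Within the data shown here, the single one-place change among them, a step that the two limits leave unreadable from compound 2 to compound 3, has no readable size. The new compound is compound 4 `COc1cc(-n2ncnc2-c2cccc(Cl)c2)cc(OC)c1OC`. It differs from compound 1 in one place: chloro in place of nitro on an aromatic carbon. Among the measured compounds shown here, no measured step bears on a change of this kind, and the only evidence is the limit of > 10000 nM in this assay, at which 3 of the 3 values shown sit, which gives no size or direction for any step in this assay. The expected outcome for compound 4 is therefore a further limit rather than a number, with no step beyond the scatter expected from compound 1. The estimated step is a step that the limit leaves unreadable from compound 1 to compound 4. For compound 4 the estimated value is 15000 nM, with a range from 5000 nM to 50000 nM.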

Compound 4, half-maximal inhibitory concentration: > 10000 nM
Compound 4 was reported as a limit; the forecaster's own chance of this, stated with the estimate: 80%; the middle value lies beyond the limit too.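

In this assay compound 4 gives > 10000 nM as a limit of the assay. Among these compounds, compound 1 also stands at a limit, so no step between compound 1 and compound 4 can be read. The compounds shown leave open whether any change on this core gives a measurable value in this assay at all.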